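The source may report more compounds than this note shows. Statements on the series, on what has been measured and on what is new or still open speak of the compounds shown alone.

Measured in an assay on membranes from HEK293 cells for displacement of a labelled ligand from adenosine receptor A2b (Homo sapiens), read by scintillation counting, with a stated time of 30 min, tested at 1 uM; on this read-out higher numbers stand for more inhibition at the one concentration tested (going by the name of the read-out) and lower numbers for less inhibition:
compound 1 `CCN(CC)C(=O)C1=C(C)NC(=O)NC1c1ccoc1`: 12%
compound 2 `CCN(CC)C(=O)C1=C(C)NC(=O)NC1c1cccs1`: 22%
compound 3 `CCC(CC)OC(=O)C1=C(C)NC(=O)NC1c1ccoc1`: 28%

Compound 4 `CCC(CC)OC(=O)C1=C(C)NC(=O)NC1c1cccs1` has not yet been measured. From compound 1 to compound 2 the change is thiophen-2-yl in place of furan-3-yl on a saturated ring carbon, and it gave a number 10 percentage points higher from compound 1 to compound 2 (within the scatter). The cores of compound 1 and compound 3 differ by (pentan-3-yl)oxy in place of diethylamino on a carbonyl carbon, a step of a number 16 percentage points higher from compound 1 to compound 3 (beyond the scatter). Compound 4 is reached from compound 3 by thiophen-2-yl in place of furan-3-yl on a saturated ring carbon. This is the same kind of change as from compound 1 to compound 2, though here the place is next to the ring atom that bears a group of 8 heavy atoms rather than a group of 7 heavy atoms. Resting on the earlier step of a number 10 percentage points higher from compound 1 to compound 2 (within the scatter), the step from compound 3 to compound 4 is expected to be a number 10 percentage points higher from compound 3 to compound 4 (within the scatter). Compound 4 is therefore estimated at 38%, most likely between 22% and 52%.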

Compound 4, a percentage reported as inhibition, at one concentration (the size of the read-out at that concentration, not a potency): 6%
Estimate against measurement, compound 4: 32 percentage points above; measured number outside the range, below it.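

Neither change carried over unchanged: in this assay, thiophen-2-yl in place of furan-3-yl gave a number 22 percentage points lower from compound 3 to compound 4 (beyond the scatter), and (pentan-3-yl)oxy in place of diethylamino gave a number 16 percentage points lower from compound 2 to compound 4 (beyond the scatter). The effect of the ring swap therefore depends on the core it is made on: the same change on two cores in this assay, a number 10 percentage points higher (within the scatter) from compound 1 to compound 2 and a number 22 percentage points lower (beyond the scatter) from compound 3 to compound 4, 32 percentage points apart, beyond the scatter of two such steps The reverse comparison gives the same picture, which shows that the two places are linked in these four compounds, but not why, nor whether this extends to other groups: the same change on two cores in this assay, a number 16 percentage points higher (beyond the scatter) from compound 1 to compound 3 and a number 16 percentage points lower (beyond the scatter) from compound 2 to compound 4, 32 percentage points apart, beyond the scatter of two such steps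

From the compounds shown here alone, it remains open whether a phenyl ring or thiophen-3-yl on the saturated ring carbon would behave like furan-3-yl or like thiophen-2-yl. The same question stands for a shorter chain such as ethoxy on the carbonyl carbon.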